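The source may hold more compounds than are shown below. What is called first, only, known or untested is meant among the compounds shown, and "the series" means these compounds.

Working notes on the series. Going by the values given here, compound 1 (`O=C1C(Nc2ccc(Br)cc2)=CC(=O)c2c1nc1n2[C@H]2OC[C@@H](O)[C@H]2OC1`) gives 4330 nM in a functional assay on MCF7 cells (Homo sapiens) for inhibition, read by sulforhodamine B assay (a lower number here means a stronger inhibitor, a higher number a weaker inhibitor), and is the only compound so far with a measured number. Compound 2 (`CCCc1ccc(NC2=CC(=O)c3c(nc4n3[C@H]3OC[C@@H](O)[C@H]3OC4)C2=O)cc1`) gives > 4000 nM in this assay and this is a limit, not a number. Among the compounds with values here, the one measured step is a step that the limit leaves unreadable from compound 1 to compound 2 and it offers no size to carry forward. The evidence on it amounts to the limit of > 4000 nM in this assay, at which 1 of the 2 values shown sits, and nothing more.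

Compound 3 (`O=C1C(NC2CCCCC2)=CC(=O)c2c1nc1n2[C@H]2OC[C@@H](O)[C@H]2OC1`) keeps the shared core and changes the group on the amine nitrogen, with cyclohexyl in place of 4-propylphenyl on an amine nitrogen as the difference. Within the data shown here, no measured step covers this kind of exchange, so no size can be borrowed, and no step beyond the scatter is expected in this assay in either direction. Among the measured compounds shown here, the expectation rests on compound 1 with 4330 nM as the one number available, and a value near that level is expected for compound 3. The expected change is a step that the limit leaves unreadable from compound 2 to compound 3 as an estimate only. The estimate for compound 3 is 5000 nM with an expected range of 1500 nM to 16000 nM in this assay for now.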

Compound 3, half-maximal inhibitory concentration: > 16000 nM
Compound 3: a limit, no number (the forecaster's own chance of this, stated with the estimate: 45%); middle value at least 3.2-fold (0.50 log units) away from the limit.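

In this assay, going by these compounds alone, the exchange of 4-bromophenyl for cyclohexyl on an amine nitrogen gives the first readable step at this position: an at least 3.6-fold higher number from compound 1 to compound 3 (0.56 log units; beyond the scatter). Within the data shown here, the change at this position can therefore move the result beyond the scatter, and the direction of this one step is towards a weaker inhibitor, although only one pair supports it and the full size remains unknown. From the compounds shown here alone, compound 3 has a limit and not a number, > 16000 nM, and the steps that involve compound 2 cannot be read, so 4-propylphenyl and cyclohexyl cannot be placed in order and the size of the bromo to propyl exchange stays unknown.

The compounds shown do not separate the loss of the aromatic ring from the loss of the bromo group, which a plain phenyl group on the same amine nitrogen would help to resolve. Going by these compounds, it also remains open how a 4-chlorophenyl group, a 4-methoxyphenyl group or an open butyl chain in this place would compare with compound 1.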